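Methoxy to Hydroxy on a Shared Core: an Expectation

The compounds below may be only part of what the source reports. "The series", "measured", "known", "first", "only" and "open" are said of these compounds alone.

Three compounds have been measured in a functional assay on IMR-32 cells (Homo sapiens) for cytotoxicity, read by sulforhodamine B assay, with a stated time of 48 h; a lower number here means a stronger inhibitor, a higher number a weaker inhibitor:

Compound 1, `COc1ccc(C2CC(c3cccc4ccccc34)=NN2C(C)=O)cc1OC`, gives 1680 nM.
Compound 2, `COc1cc(C2CC(c3cccc4ccccc34)=NN2C(C)=O)ccc1O`, gives 1780 nM.
Compound 3, `COc1ccc(C2CC(c3ccc4ccccc4c3)=NN2CC=O)cc1OC`, gives 1590 nM.

Compound 2 differs from compound 1 by hydrogen in place of methyl on an oxygen on an aromatic ring, a change that gave a 1.1-fold higher number from compound 1 to compound 2 (0.03 log units; within the scatter). Compound 3 carries the same atoms as compound 1 joined differently; the difference between the two cores is not broken down here. In this assay compound 3 and compound 1 sit within the scatter of each other.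

Compound 4, `COc1ccc(C2CC(c3ccc4ccccc4c3)=NN2CC=O)cc1O`, differs from compound 3 by hydrogen in place of methyl on an oxygen on an aromatic ring, the same change seen in the pair above, at an identically described place. Because a 1.1-fold higher number from compound 1 to compound 2 (0.03 log units; within the scatter) lay within the scatter, the step of a 1.1-fold higher number from compound 3 to compound 4 (0.04 log units; within the scatter) is expected to be of the same small size. Compound 4 is therefore estimated at 1750 nM, with a likely range from 900 nM to 3500 nM.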

Compound 4, half-maximal inhibitory concentration: 1490 nM
The estimate for compound 4 lay 1.2-fold (0.07 log units) above the measured number, and the stated range covers the measured number.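

In this assay, the change from methoxy to hydroxy on the second core gave a 1.1-fold lower number from compound 3 to compound 4 (0.03 log units; within the scatter), and the two steps compare as follows: the same change on two cores in this assay, a 1.1-fold higher number (0.03 log units; within the scatter) from compound 1 to compound 2 and a 1.1-fold lower number (0.03 log units; within the scatter) from compound 3 to compound 4, 1.1-fold (0.05 log units) apart, within the scatter of two such steps. Across these two cores, then, the change carried over with no step beyond the scatter and no difference between the steps beyond it. This does not show a direction for the change, nor that the same would hold on any other core or in any other assay, since only two pairs are shown.

The compounds shown leave open whether a longer chain on that oxygen would give a step beyond the scatter. The same question stands for an amine or a carboxylic acid in place of the hydroxy group.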